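Moving the Fluorine of Compound 1 One Position

This account rests on a few compounds, and the source may have more. Where it says the series, first, only, none or still open, it means among the compounds named here.

Compound 1 `CC(C)Cc1nn(-c2nccs2)cc1C(=O)NCc1cccc(F)c1` was examined in a toxicity assay on HepG2 2.2.15 cells (Homo sapiens) for cytotoxicity, read by CCK-8 assay, with a stated time of 8 days; on this read-out lower numbers stand for higher toxicity in this test and higher numbers for lower toxicity in this test. In this assay compound 1 gives only a limit, > 100000 nM. Compound 2 `CCOC(=O)c1cn(-c2ccccc2F)nc1CC(C)C` likewise reaches only a limit of > 100000 nM in this assay. Compound 3 `CCOC(=O)c1cn(-c2ccc(C(=O)O)cc2)nc1CC(C)C` also stops at a limit, > 100000 nM. All three measured values therefore sit at the limit of > 100000 nM in this assay, at which 3 of the 3 values shown sit, and compound 1 stands level with the others at that limit, with no number below it. Compound 4 `CC(C)Cc1nn(-c2nccs2)cc1C(=O)NCc1ccc(F)cc1` differs from compound 1 by 4-fluorophenyl in place of 3-fluorophenyl on a saturated chain carbon bound to an amide-type nitrogen. Among the measured compounds shown here, no step between two measured compounds is available, so in this assay the step is expected to be none beyond the scatter: a number no higher from compound 1 to compound 4 (the limit leaves the size open). Compound 4 is estimated at 100000 nM, between 50000 nM and 200000 nM, most likely again reported as a limit.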

Compound 4, half-maximal cytotoxic concentration: > 100000 nM
Compound 4 gave a limit, no number; the forecaster's own chance of this, stated with the estimate: 85%; the middle value lies on the limit itself.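

Compound 1 and compound 4 both give only a limit, so no step can be read between them: the limit of > 100000 nM in this assay, at which 4 of the 4 values shown sit.

The compounds shown leave open whether 4-fluorophenyl and 3-fluorophenyl differ at all in this assay.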